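One stereocentre drawn as S

A few compounds are considered here, and "the series" means these few. Any claim that something is new, unique, unknown or untested is made for them only; others in the source may bear on it.

In an ADME assay on liver (Homo sapiens) for metabolic stability, read by LC-MS, using microsomes and NADPH (a lower number here means that less of the compound is left, a higher number that more of the compound is left), compound 2 (`Cc1cc(CN(CC2CC2)C(CC(=O)O)c2ccc(Cl)cc2)ccc1OCCN1C(=O)CCC1=O`) stands at 96% and compound 1 (`CCCN(Cc1ccc(OCCN2C(=O)CCC2=O)c(C)c1)[C@@H](CC(=O)O)c1ccc(Cl)cc1`) at 97% with the two values within the scatter of each other. Compound 3 (`Cc1cc(CN(CC2CC2)[C@@H](CC(=O)O)c2ccc(Cl)cc2)ccc1OCCN1C(=O)CCC1=O`) has the same atoms and bonds as compound 2 (the two compounds have the same atoms and bonds; at least one stereo element is drawn with a configuration in one of them and without one in the other: 1 of 1 stereo elements differ; a stereocentre at a saturated chain carbon is drawn without a configuration in compound 2 and S in compound 3) and its stereocentre at a saturated chain carbon is drawn S instead of without a configuration. Going by the values given here, no measured step covers this change, so no step beyond the scatter is expected in this assay for it. The estimated a number 1 percentage points lower from compound 2 to compound 3 (within the scatter) stays within that scatter. For compound 3 the expected value is 95% with an estimated range from 85% to 100% as the likely span.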

Compound 3, percent of the compound remaining: 90%
The estimate for compound 3 lay 5 percentage points above the measured number; low and high end bracket the measured number.
By their numbers in this assay, from the lowest: compounds 3, 2 and 1 (each within the scatter of the next).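

In this assay, drawing the stereocentre at a saturated chain carbon as S gives a number 6 percentage points lower from compound 2 to compound 3 (within the scatter), so defining this centre shows no change beyond the scatter. With S drawn in both compounds, cyclopropyl in place of ethyl gives a number 7 percentage points lower from compound 1 to compound 3 (within the scatter), so this change does not separate them either. The stereo step rests on a single difference: the fact that one of compounds 2 and 3 is drawn with a defined configuration and the other without, at the place where they differ

The compounds shown leave open how the R form behaves in this assay. They also leave open what a longer chain, such as butyl, would give in place of cyclopropyl.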